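Extending the amide side chain of compound 2

The source may report more compounds than this note shows. Statements on the series, on what has been measured and on what is new or still open speak of the compounds shown alone.

In an ADME assay on the whole organism (strain CD1) for pharmacokinetics, with Mus musculus as the target, read by LC-MS, at a dose of 5 mg/kg by the intravenous route (a higher number here means faster removal of the compound, a lower number slower removal), compound 1 (`Cc1c(Oc2cnc(C(=O)NCCO)cn2)ccc2c1B(O)OC2`) gives 2.65 mL/min/kg and compound 2 (`Cc1c(Oc2cnc(C(=O)NC(C)CO)cn2)ccc2c1B(O)OC2`) gives 2.13 mL/min/kg. The two values lie within the scatter of each other, so compound 2 stands level with compound 1, and both sit at small numbers.

Compound 3 (`CCC[C@H](CO)NC(=O)c1cnc(Oc2ccc3c(c2C)B(O)OC3)cn1`) keeps the shared core and alters only the group on the amide-type nitrogen: 1-(hydroxymethyl)butyl in place of 1-(hydroxymethyl)ethyl on an amide-type nitrogen. Among the measured compounds shown here, only one measured step bears on this change. It is a 1.2-fold lower number from compound 1 to compound 2 (0.09 log units; within the scatter), and it came from methyl in place of hydrogen on a saturated chain carbon of the same side chain. For the measured compounds named here, that single step shows no clear response in this assay to a small change at this place, but the chain change in compound 3 is larger, and no measured compound carries a chain of this length. A small move towards a higher number is therefore expected, without any step beyond the scatter. The expected change is a 1.5-fold higher number from compound 2 to compound 3 (0.19 log units; within the scatter). Compound 3 is estimated at 3.3 mL/min/kg, with an expected range of 1.5 mL/min/kg to 7.5 mL/min/kg.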

Compound 3, clearance: 4.05 mL/min/kg
Compound 3: the middle estimate sits 1.2-fold (0.09 log units) below what was measured, within the range that was stated.
By their numbers in this assay, from the lowest: compounds 2, 1 and 3 (each within the scatter of the next).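

With the 1-(hydroxymethyl)butyl group on the amide-type nitrogen, the measured change in this assay is a 1.9-fold higher number from compound 2 to compound 3 (0.28 log units; within the scatter), and the same side chain set against that of compound 1 gives a 1.5-fold higher number from compound 1 to compound 3 (0.18 log units; within the scatter). The earlier compounds had shown only the small methyl change at this place, whereas these steps show that the larger propyl change also stays within the scatter, so compound 1, compound 2 and compound 3 stand level and no dependence on chain length can be claimed from them. No supporting measurement is available that could explain these clearance values.

The compounds shown leave open whether a longer chain on the same carbon, or a ring there, would carry the number beyond the scatter, and whether the three-compound picture would hold with an amine or a carboxylic acid in place of the hydroxyl. They also leave open what the defined stereocentre of the 1-(hydroxymethyl)butyl group contributes, as its mirror-image form is not among them.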